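The source may report more compounds than this note shows. Statements on the series, on what has been measured and on what is new or still open speak of the compounds shown alone.

Three compounds share one core and differ only in the ester at one end. Compound 1 `CC(=O)Oc1ccccc1C(=O)O[C@H]1CO[C@H]2[C@@H]1OC[C@H]2OC(=O)c1cccc(C)c1` gives 0.165 h in an ADME assay on a cell-free system (plasma, Homo sapiens) for metabolic stability, with Plasma (Rattus norvegicus) as the target, read by HPLC, at pH 7.4; a higher number here means that the compound lasts longer, a lower number that the compound disappears faster. Compound 2 `CC(=O)Oc1ccccc1C(=O)O[C@H]1CO[C@H]2[C@@H]1OC[C@H]2OC(=O)c1ccc(C)cc1` gives 0.105 h in this assay, and compound 3 `CC(=O)Oc1ccccc1C(=O)O[C@H]1CO[C@H]2[C@@H]1OC[C@H]2OC(=O)c1ccc([N+](=O)[O-])cc1` gives 0.0462 h. Compound 3 therefore stands at the bottom of the three numbers: the change a 3.6-fold lower number from compound 1 to compound 3 (0.55 log units; beyond the scatter) and the change a 2.3-fold lower number from compound 2 to compound 3 (0.36 log units; beyond the scatter) both lie beyond the scatter, whereas a 1.6-fold lower number from compound 1 to compound 2 (0.20 log units; within the scatter) does not.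

Compound 4 `CC(=O)Oc1ccccc1C(=O)O[C@H]1CO[C@H]2[C@@H]1OC[C@H]2OC(=O)CCO[N+](=O)[O-]` carries the change (2-(nitrooxy)ethyl in place of 4-nitrophenyl on a carbonyl carbon). For the measured compounds named here, none of the measured steps probes this kind of change; all three concern substituents on a six-membered aromatic ring, and the 4-nitrophenyl group now leaves altogether. The expectation can therefore rest only on the low position of compound 3 at 0.0462 h, and the step of a 1.2-fold lower number from compound 3 to compound 4 (0.06 log units; within the scatter) is expected to be small and uncertain. Compound 4 is estimated at 0.04 h in this assay, within a range from 0.012 h to 0.13 h.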

Compound 4, half-life: 0.065 h
Compound 4: middle estimate off by 1.6-fold (0.21 log units), on the low side; the measured number falls inside the stated range.
By their numbers in this assay, from the lowest: compounds 3, 4, 2 and 1 (each within the scatter of the next, the first and the last beyond it).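

With the six-membered aromatic ring gone from this ester, this assay gives a 1.4-fold higher number from compound 3 to compound 4 (0.15 log units; within the scatter) and a 1.6-fold lower number from compound 2 to compound 4 (0.21 log units; within the scatter) so an aromatic ring on this carbonyl carbon is not needed for a half-life in the range of these two compounds. Only against the 3-methylphenyl ester does the open chain stand apart, with a 2.5-fold lower number from compound 1 to compound 4 (0.40 log units; beyond the scatter) and that gap is no larger than the one already printed for the 4-nitrophenyl ester. Nothing at hand explains why the half-lives fall as they do.

The compounds shown leave open whether the nitrooxy end or the chain itself sets this number, which a plain ethyl group or a longer chain carrying the same nitrooxy end would help to separate. On these data alone, an amine or a carboxylic acid at the end of the chain also remains untested here.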